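Isobutyl for Cyclopropyl on the Carbonyl Carbon

This account rests on a few compounds, and the source may have more. Where it says the series, first, only, none or still open, it means among the compounds named here.

Measured so far:
Compound 1, `CCCOC(=O)C1=C(C)NC(=O)NC1c1ccco1`: 3%
Compound 2, `CC1=C(C(=O)OC(C)C)C(c2cccs2)NC(=O)N1C`: 17%
Compound 3, `CC1=C(C(=O)C2CC2)C(c2ccco2)NC(=O)N1`: 7%

Three compounds sharing one core were tested in an assay on membranes from HeLa cells for displacement of a labelled ligand from adenosine receptor A3 (Homo sapiens), read by scintillation counting, with a stated time of 180 min, tested at 1 uM; on this read-out higher numbers stand for more inhibition at the one concentration tested (going by the name of the read-out) and lower numbers for less inhibition. Compound 3 gives 7%, the second highest of the three numbers. Its nearest neighbour is compound 1 with 3%, a gap within the usual scatter. The furthest is compound 2 with 17%, a gap also within the scatter, so none of the three numbers can be set apart from the others as higher or lower.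

Compound 4, `CC1=C(C(=O)CC(C)C)C(c2ccco2)NC(=O)N1`, has not yet been measured. It differs from compound 3 in one place: isobutyl in place of cyclopropyl on a carbonyl carbon. Among the compounds with values here, only one measured step touches that same carbonyl carbon, a number 4 percentage points higher from compound 1 to compound 3 (within the scatter), and it stayed within the scatter. Compound 2 differs from compound 3 in more than one place, so its value offers no guidance on this single change. Within the data shown here, with the one relevant step showing no movement beyond the scatter, compound 4 is expected to show a step of a number 1 percentage points higher from compound 3 to compound 4 (within the scatter), that is, none beyond the scatter. Compound 4 is therefore estimated at 8%, with a range from 0% to 20%.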

Compound 4, a percentage reported as inhibition, at one concentration (the size of the read-out at that concentration, not a potency): 31%
The estimate for compound 4 lay 23 percentage points below the measured number; measured number above the stated range.
By their numbers in this assay, from the lowest: compounds 1, 3 and 2 (each within the scatter of the next, the first and the last beyond it); then compound 4.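

At this carbonyl carbon the earlier step, a number 4 percentage points higher from compound 1 to compound 3 (within the scatter), gave no movement beyond the scatter, so the position had not yet shown any response to a change of group. In this assay it now does: with isobutyl in place of cyclopropyl the result is a number 24 percentage points higher from compound 3 to compound 4 (beyond the scatter), and with isobutyl in place of propoxy it is a number 28 percentage points higher from compound 1 to compound 4 (beyond the scatter), so among these three groups on the same carbon only isobutyl separates from the others, while cyclopropyl and propoxy remain within the scatter of each other. Nothing measured here explains why this open-chain group gives the higher number.

As far as these compounds go, it remains open whether a longer chain, a phenyl group or an amine on this carbonyl carbon would give a still higher number or lose the gain, and whether the same change would have a comparable effect on the core of compound 2. Since each compound was read at one concentration only, these numbers show the size of inhibition at that concentration and leave the potency of compound 4 undetermined.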